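A few compounds are considered here, and "the series" means these few. Any claim that something is new, unique, unknown or untested is made for them only; others in the source may bear on it.

Measured so far:
compound 1, `CC[C@H](C)[C@@H]1C(=O)N[C@H](C2Cc3ccccc3C2)C(=O)N1[C@@H](C(=O)N(C)C)c1ccc(C)nc1C`, 14 mL.min-1.g-1
compound 2, `CC[C@@H](C)[C@@H]1C(=O)N[C@H](C2Cc3ccccc3C2)C(=O)N1[C@@H](C(=O)N1CCOCC1)c1ccc(C)nc1`, 8 mL.min-1.g-1
compound 3, `Cc1ccc([C@H](C(=O)N(C)C)N2C(=O)[C@@H](C3Cc4ccccc4C3)NC(=O)[C@H]2CC(C)C)cn1`, 21000 mL.min-1.g-1

In an in vitro ADME assay on microsomes from liver (Macaca fascicularis) for metabolic stability (a higher number here means faster removal of the compound, a lower number slower removal), compound 1 gives 14 mL.min-1.g-1. Its nearest neighbour is compound 2, whose 8 mL.min-1.g-1 lies within the usual scatter of repeated measurements, so the two cannot be separated. For the measured compounds named here, compound 3, at 21000 mL.min-1.g-1, lies far beyond the scatter on the high side; compound 3 differs from compound 1 in more than one place, so no single step can be drawn between them.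

Compound 4, `CC[C@H](C)[C@@H]1C(=O)N[C@H](C2Cc3ccccc3C2)C(=O)N1[C@@H](C(=O)N(C)C)c1cnc(C)cc1C`, arises from compound 1 by one change: 4,6-dimethylpyridin-3-yl in place of 2,6-dimethylpyridin-3-yl on a saturated chain carbon bound to an amide-type nitrogen in a ring and a carbonyl carbon. The rest of the core of compound 1 is kept. Going by the values given here, no measured pair shows this change, so its size has to be judged from the narrow spread of compounds 1 and 2 alone. For compound 4 the expected step is a 1.8-fold higher number from compound 1 to compound 4 (0.25 log units; within the scatter), modest and probably upward, though not clearly beyond the scatter. Compound 4 is therefore estimated at 25 mL.min-1.g-1 in this assay, with a likely range from 8 mL.min-1.g-1 to 90 mL.min-1.g-1.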

Compound 4, intrinsic clearance in microsomes: 32 mL.min-1.g-1
Compound 4: middle estimate off by 1.3-fold (0.11 log units), on the low side; low and high end bracket the measured number.
By their numbers in this assay, from the lowest: compounds 2 and 1 (each within the scatter of the next); then compound 4; then compound 3.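

In this assay, for the compounds shown here, putting 4,6-dimethylpyridin-3-yl in place of 2,6-dimethylpyridin-3-yl gives a 2.3-fold higher number from compound 1 to compound 4 (0.36 log units; beyond the scatter), the first single change in this set whose size can be read. The two groups hold the same atoms joined differently, so the number at this place on the saturated chain carbon responds to the arrangement of the group alone, not only to what atoms it contains, though the step is modest and only just clears the scatter. Nothing measured here accounts for the step, and no supporting data bear on it.

This one step does not show whether the change would have the same size with the morpholine amide of compound 2 or the side chain of compound 3. Going by these compounds, how a methoxy group or a trifluoromethyl group on the pyridine would fare also remains open.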